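Acetylating the free hydroxy of compound 1

A few compounds are considered here, and "the series" means these few. Any claim that something is new, unique, unknown or untested is made for them only; others in the source may bear on it.

Measured in a physicochemical assay for lipophilicity; on this read-out higher numbers stand for higher lipophilicity and lower numbers for lower lipophilicity:
- Compound 1 `CC(=O)O[C@H]1[C@H](O)[C@@H](CO)O[C@H]1n1cnc2c(N)ncnc21` gives -0.18
- Compound 2 `CC(C)C(=O)O[C@H]1[C@H](OC(=O)C(C)C)[C@@H](CO)O[C@H]1n1cnc2c(N)ncnc21` gives 1.74
- Compound 3 `CC(=O)OC[C@H]1O[C@@H](n2cnc3c(N)ncnc32)[C@@H](O)[C@@H]1OC(C)=O` gives 0.72

Compound 1 has the lowest of the three numbers. The nearest number belongs to compound 3, and the furthest to compound 2. Both lie above compound 1 and beyond the usual scatter.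

The next compound to be measured is compound 4 `CC(=O)O[C@H]1[C@H](OC(C)=O)[C@@H](CO)O[C@H]1n1cnc2c(N)ncnc21`. It differs from compound 1 in one place: acetyl in place of hydrogen on an oxygen on a saturated carbon. In words, this is acetyl in place of hydrogen on an oxygen on a saturated carbon, or hydroxy to acetoxy.

Among the compounds with values here, no two measured compounds differ in one place, so this change has no direct precedent. The closest reference is compound 3 (0.72) , an isomer of compound 4 with its acetyl groups placed differently. Compound 4 is therefore expected to land near compound 3 and not near compound 2 (1.74) .

The expected move in this assay is upward and beyond the scatter, with an estimated size of a number 0.73 log units higher from compound 1 to compound 4 (beyond the scatter) in this read-out.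

Compound 4 is expected at 0.55 with an estimated range of 0.15 to 0.95 in this read-out.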

Compound 4, partition coefficient: 0.2
For compound 4 the middle estimate is 0.35 log units above the measured one; the measured number falls inside the stated range.
By their numbers in this assay, from the lowest: compound 1; then compound 4; then compound 3; then compound 2.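

Within the data shown here, compound 1 and compound 4 form the first pair that differs in one place, so the effect of a single change can now be read directly. In this assay, acetyl in place of hydrogen on an oxygen on a saturated carbon, or hydroxy to acetoxy, gives a number 0.38 log units higher from compound 1 to compound 4 (beyond the scatter). This position therefore registers the change on this read-out, though the step is modest and rests on one pair; no supporting data are available to explain its size or direction.

From the compounds shown here alone, whether a longer chain in the ester, such as butyryl, or a simple methyl ether at this oxygen would give a larger or smaller step than acetyl remains open, as does the result of replacing the hydroxy with an amine. Going by these compounds, it is also open whether acetyl in place of hydrogen on the remaining free hydroxy of compound 4 would give a step of similar size, since one pair cannot show whether this step carries over to another oxygen in the shared core.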